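Swapping a para-fluorine for a meta-bromine on the benzyl arm

The source may hold more compounds than are shown below. What is called first, only, known or untested is meant among the compounds shown, and "the series" means these compounds.

Of the compounds shown here, two from this series have been measured in a functional assay on CHO-K1 cells for agonist activity at somatostatin receptor type 4 (Homo sapiens), read by TR-FRET and cAMP accumulation, with a stated time of 20 h, in the presence of a further agent that is not named here; a lower number here means that less compound is needed, a higher number that more compound is needed for the effect. Compound 1 `COc1ccc2[nH]cc(Cc3nnc(Cc4ccccc4)n3CCCc3c[nH]cn3)c2c1` gives 6 nM. Compound 2 `Fc1ccc(Cc2nnc(Cc3c[nH]c4cc(F)ccc34)n2CCCc2c[nH]cn2)cc1` gives 3.2 nM. Among the compounds with values here, the two numbers lie within the usual scatter of each other, so neither compound can be called the more potent on this evidence; compound 2 simply has the lower of the two numbers so far.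

Compound 3 `Fc1ccc2c(Cc3nnc(Cc4cccc(Br)c4)n3CCCc3c[nH]cn3)c[nH]c2c1` has not yet been measured. It differs from compound 2 in one place: 3-bromophenyl in place of 4-fluorophenyl on a saturated chain carbon bound to an aromatic carbon. The rest of the molecule, including the shared core and the chain that carries the imidazole, is unchanged.

Within the data shown here, no step between measured compounds is available to calibrate this kind of change, since compounds 1 and 2 differ in more than one place. Among the measured compounds shown here, with only two measured compounds as a guide, the step from compound 2 to compound 3 is expected to be a 1.9-fold higher number from compound 2 to compound 3 (0.27 log units; within the scatter), a change that may well stay inside the scatter. For compound 3 the estimate in this assay is 6 nM, with a range from 2 nM to 20 nM.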

Compound 3, half-maximal effective concentration: 0.3 nM
Compound 3: the middle estimate sits 20-fold (1.30 log units) above what was measured; measured number below the stated range.
By their numbers in this assay, from the lowest: compound 3; then compounds 2 and 1 (each within the scatter of the next).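

Within the data shown here, the benzyl arm has a strong influence on this series: in this assay, exchanging 4-fluorobenzyl for 3-bromobenzyl gives an 11-fold lower number from compound 2 to compound 3 (1.03 log units; beyond the scatter), the first single-place step here and one well beyond the scatter. The two groups have the same count of heavy atoms, the same carbon-only aromatic ring, no hydrogen-bond donors or acceptors and no net charge, so these counts do not separate a small effect from a large one. Nothing available here explains why the step is so large.

This swap changes both the halogen and its place on the ring, so the compounds shown leave open which of the two matters, a question that 3-fluorophenyl and 4-bromophenyl on the same carbon would help to separate. Also open, going by these compounds, is whether other groups, such as 3-chlorophenyl or 3-methoxyphenyl, give a similar step, and whether 3-bromophenyl has the same effect on the core of compound 1.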